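A few compounds are considered here, and "the series" means these few. Any claim that something is new, unique, unknown or untested is made for them only; others in the source may bear on it.

Measured so far in a physicochemical assay for lipophilicity, measured as octanol-water partition; on this read-out lower numbers stand for lower lipophilicity and higher numbers for higher lipophilicity:
- compound 1 `Cc1cc(Cl)cc(C)c1OCC(C)O`: 3.52
- compound 2 `Cc1cccc(Cl)c1OCCCO`: 2.93

Compound 1 stands highest of the two numbers, and compound 2 lies lower by a gap beyond the usual scatter of repeated measurements.

The next compound to be measured is compound 3 `Cc1cc(Cl)cc(C)c1OCCCO`, which has the same atoms as compound 1, joined differently. The structural change is 2-hydroxyethyl in place of 1-hydroxyethyl on a saturated chain carbon bound to an oxygen on an aromatic ring. The same difference, cut one bond further out, reads 2-hydroxypropyl to 3-hydroxypropyl.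

For the measured compounds named here, no measured pair shows this change, so the data offer no direct precedent for its size. With the atoms unchanged, only a small downward step in this assay is expected, none beyond the scatter, starting from compound 1 at 3.52. The estimated move is a number 0.12 log units lower from compound 1 to compound 3 (within the scatter). The expected value for compound 3 is 3.4, with an estimated range of 3.1 to 3.7.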

Compound 3, partition coefficient: 3.72
Beside the measured number, compound 3's estimate is 0.32 log units below it; measured number above the stated range.
By their numbers in this assay, from the lowest: compound 2; then compounds 1 and 3 (each within the scatter of the next).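

In this assay, the exchange of 1-hydroxyethyl for 2-hydroxyethyl on a saturated chain carbon bound to an oxygen on an aromatic ring reads as a number 0.20 log units higher from compound 1 to compound 3 (within the scatter) and gives the first direct measure of this change in the series. The two compounds share the same atoms and the same core, and the exchange keeps the counted hydrogen-bond donor and acceptor unchanged, so this pair gives the first sign that the position of the hydroxyl on this short chain can be altered without a step beyond the scatter on this read-out. No measured evidence is available to explain the size of this step.

This is a single pair on a single core, so it sets no rule for the same exchange on other cores. From the compounds shown here alone, what a longer chain, an amine or a carboxylic acid would give at this place in the same read-out remains open.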